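This account rests on a few compounds, and the source may have more. Where it says the series, first, only, none or still open, it means among the compounds named here.

Of the compounds shown here, two sharing one core have been tested in a toxicity assay on Huh-7 cells (Homo sapiens) for cytotoxicity, with a stated time of 3 days; a higher number here means that more compound is tolerated, a lower number that less compound is tolerated. For compound 1 `COc1ccc(-c2cn([C@@H]3O[C@H](CO)[C@@H](O)[C@@]3(C)O)c3ncnc(N)c23)cc1`, which carries 4-methoxyphenyl, the assay reports only a limit, > 44000 nM. Among the measured compounds shown here, compound 2 `C[C@@]1(O)[C@H](O)[C@@H](CO)O[C@H]1n1cc(-c2cccs2)c2c(N)ncnc21`, with thiophen-2-yl in its place, gives 48100 nM, the only actual number available in this assay. Compound 3 `C[C@@]1(O)[C@H](O)[C@@H](CO)O[C@H]1n1cc(-c2ccoc2)c2c(N)ncnc21` differs from compound 2 by a single exchange, furan-3-yl in place of thiophen-2-yl on an aromatic carbon.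

For the measured compounds named here, one measured step bears on this exchange, and it concerns a different pair of groups. It is a step that the limit leaves unreadable from compound 1 to compound 2, so it offers no size to carry over. The evidence also includes (the limit of > 44000 nM in this assay, at which 1 of the 2 values shown sits). With no readable step to suggest otherwise, the expectation rests on compound 2 at 48100 nM, and no change beyond the usual scatter is expected in this assay, in either direction. The assay may also return only a limit for the new compound. The expected step is a 1.0-fold higher number from compound 2 to compound 3 (0.02 log units; within the scatter). Compound 3 is estimated at 50000 nM, with an expected range from 24000 nM to 96000 nM.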

Compound 3, half-maximal cytotoxic concentration: > 44000 nM
Compound 3 ended at the assay's limit; the forecaster's own chance of this, stated with the estimate: 40%; the middle value does not contradict the limit.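

In this assay compound 3 returns only a limit, > 44000 nM. Among the compounds shown here, no step from compound 1 or compound 2 to compound 3 can be read. Whether furan-3-yl, thiophen-2-yl and 4-methoxyphenyl differ at all in this assay stays open, because only compound 2 has an actual number: the limit of > 44000 nM in this assay, at which 2 of the 3 values shown sit.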